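Three Inactive Analogues and a Pyrazolyl Replacement

This account rests on a few compounds, and the source may have more. Where it says the series, first, only, none or still open, it means among the compounds named here.

Compound 1 `c1ccc(-c2cccc3c2CCC3c2ncc[nH]2)nc1`: in a functional assay on CHO cells for agonist activity at Alpha-1D adrenergic receptor (Homo sapiens), read by FLIPR and calcium flux (a lower number here means that less compound is needed, a higher number that more compound is needed for the effect), compound 1 gives > 10000 nM, which is a limit of the assay.
Compound 2 `Cn1nccc1-c1cccc2c1CCC2c1ncc[nH]1`: in this assay compound 2 gives > 10000 nM, a limit of the assay.
Compound 3 `CCS(=O)(=O)Nc1cccc2c1CCC2c1ncc[nH]1`: in this assay compound 3 gives > 10000 nM, again a limit of the assay.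

Compound 3 therefore stands at the same limit as both others; the evidence is the limit of > 10000 nM in this assay, at which 3 of the 3 values shown sit. The steps a step that the two limits leave unreadable from compound 1 to compound 2, a step that the two limits leave unreadable from compound 1 to compound 3 and a step that the two limits leave unreadable from compound 2 to compound 3 are all unreadable in size, since both ends sit at the limit.

Compound 4 `c1cc(-c2cn[nH]c2)c2c(c1)C(c1ncc[nH]1)CC2` differs from compound 3 by 1H-pyrazol-4-yl in place of (ethylsulfonyl)amino on an aromatic carbon. Going by the values given here, no measured step bears on this change with a readable size. Compound 2 carries a related 1-methyl-1H-pyrazol-5-yl group and sits at the limit, so compound 4 is expected to remain weak. The estimated step is a step that the limit leaves unreadable from compound 3 to compound 4. Compound 4 is expected to give about 15000 nM, between 3000 nM and 60000 nM, in this assay.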

Compound 4, half-maximal effective concentration: 319 nM
Estimate against measurement, compound 4: 47-fold (1.67 log units) above, and the stated range ends above it.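

On this aromatic carbon of the shared core, a substituent can give a readable agonist response in this assay, whereas the steps among compounds 1, 2 and 3 cannot be read. 1H-pyrazol-4-yl gives an at least 31-fold lower number from compound 3 to compound 4 (1.49 log units; beyond the scatter) and an at least 31-fold lower number from compound 1 to compound 4 (1.49 log units; beyond the scatter). A pyrazole ring alone is not enough, as the change from the related 1-methyl-1H-pyrazol-5-yl group gives an at least 31-fold lower number from compound 2 to compound 4 (1.49 log units; beyond the scatter).

That last change alters both the ring's methyl group and its point of attachment, and the compounds shown do not separate the two. Also open, going by these compounds, is how 1-methyl-1H-pyrazol-4-yl, 1H-pyrazol-5-yl or a carboxylic acid would behave on this carbon.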